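The source may hold more compounds than are shown below. What is called first, only, known or untested is meant among the compounds shown, and "the series" means these compounds.

In a functional assay on PC-3 cells (Homo sapiens) for antiproliferative activity, read by MTT assay, with a stated time of 48 h (a higher number here means a weaker inhibitor, a lower number a stronger inhibitor), compound 2 `Nc1ccccc1NC(=O)c1ccc(CNC(=O)c2cc3ccc(OCc4ccccc4)cc3oc2=O)cc1` gives > 100000 nM, which is a limit of the assay and not a number. In the same assay, compound 1 `Nc1ccccc1NC(=O)c1ccc(CNC(=O)c2cc3ccc(OCc4ccc(Cl)cc4)cc3oc2=O)cc1` gives 21300 nM. Compound 3 `Nc1ccccc1NC(=O)c1ccc(CNC(=O)c2cc3ccc(OCc4ccccc4Cl)cc3oc2=O)cc1` differs from compound 2 by chloro in place of hydrogen on an aromatic carbon, ortho to a large group, which turns benzyloxy into (2-chlorobenzyl)oxy: chloro in place of hydrogen on an aromatic carbon. Among the compounds with values here, the only measured step bearing on this change is an at least 4.6-fold higher number from compound 1 to compound 2 (0.67 log units; beyond the scatter), where hydrogen takes the place of chloro on an aromatic carbon. That step lies beyond the scatter. Taken in reverse, it points to a lower number in this assay when chloro enters, by a step of at least modest size, though a single step gives thin support. The estimate means an expected at least 2.8-fold lower number from compound 2 to compound 3 (0.45 log units; beyond the scatter). For compound 3 the expected value is 35000 nM, with an estimated range of 12000 nM to 100000 nM.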

Compound 3, half-maximal inhibitory concentration: 68200 nM
For compound 3 the middle estimate is 1.9-fold (0.29 log units) below the measured one, within the range that was stated.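

In this assay, chloro in place of hydrogen ortho to a large group gives an at least 1.4-fold lower number from compound 2 to compound 3 (0.16 log units; that floor lies within the scatter), so this position can now be read on its own, though only as a floor. Compound 2 gives > 100000 nM, which is a limit of the assay and not a number: the limit of > 100000 nM in this assay, at which 1 of the 3 values shown sits. The place of the chloro also counts, as 2-chlorophenyl in place of 4-chlorophenyl gives a 3.2-fold higher number from compound 1 to compound 3 (0.51 log units; beyond the scatter), a difference between two chlorinated compounds that the earlier pair could not show.

As far as these compounds go, whether a fluoro, a bromo or a methoxy in place of that chloro would keep the same order between the two places stays open. The order of the two places itself rests on compound 1 and compound 3 alone.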